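Swapping the Amide Aryl Group: Compound 3 to Compound 4

The source may hold more compounds than are shown below. What is called first, only, known or untested is meant among the compounds shown, and "the series" means these compounds.

Of the compounds shown here, three sharing one core have been tested in a functional assay on Bel-7402 cells (Homo sapiens) for cytotoxicity, read by MTT assay; on this read-out lower numbers stand for stronger inhibition and higher numbers for weaker inhibition. Compound 1 `CCn1cc(C(=O)Nc2ccccc2O)c(=O)c2cc(F)c(N3CCNC(C)C3)c(F)c21` carries a 2-hydroxyphenyl group on the amide nitrogen; in this assay compound 1 reaches only the limit > 50000 nM. Compound 2 `CCn1cc(C(=O)Nc2ccccc2N)c(=O)c2cc(F)c(N3CCNC(C)C3)c(F)c21` bears a 2-aminophenyl group in that place and gives 4800 nM. Compound 3 `CCn1cc(C(=O)Nc2ccc(Cl)cn2)c(=O)c2cc(F)c(N3CCNC(C)C3)c(F)c21` carries a 5-chloropyridin-2-yl group and gives 4900 nM, the higher of the two measured numbers, with compound 2 nearest and within the scatter. The change from compound 1 to compound 3 is an at least 10-fold lower number from compound 1 to compound 3 (1.00 log units; beyond the scatter), while from compound 2 to compound 3 it is a 1.0-fold higher number from compound 2 to compound 3 (0.01 log units; within the scatter).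

Compound 4 `CCn1cc(C(=O)Nc2ccc(C)c([N+](=O)[O-])c2)c(=O)c2cc(F)c(N3CCNC(C)C3)c(F)c21` has not yet been measured. It differs from compound 3 in that (4-methyl-3-nitrophenyl in place of 5-chloropyridin-2-yl on an amide-type nitrogen). The two measured steps at this position show that the group on the amide nitrogen can take the number from a limit to a measurable value, as seen in an at least 10-fold lower number from compound 1 to compound 3 (1.00 log units; beyond the scatter), or leave it unchanged, as in a 1.0-fold higher number from compound 2 to compound 3 (0.01 log units; within the scatter). For the measured compounds named here, no measured compound bears a 4-methyl-3-nitrophenyl group, so the step of a 1.2-fold higher number from compound 3 to compound 4 (0.09 log units; within the scatter) is expected to stay modest, in either direction. Compound 4 is therefore estimated at 6000 nM, within a range from 2000 nM to 30000 nM.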

Compound 4, half-maximal inhibitory concentration: 29100 nM
Compound 4: middle estimate off by 4.9-fold (0.69 log units), on the low side; the range from low to high includes it.
By their numbers in this assay, from the lowest: compounds 2 and 3 (each within the scatter of the next); then compound 4. At a limit, above all of these: compound 1.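

In this assay compounds 2 and 3 had suggested that quite different groups on the amide nitrogen could give values within the scatter of each other, but the 4-methyl-3-nitrophenyl group separates from both, with a 5.9-fold higher number from compound 3 to compound 4 (0.77 log units; beyond the scatter) and a 6.1-fold higher number from compound 2 to compound 4 (0.78 log units; beyond the scatter) as the two steps. Until now, only the 2-hydroxyphenyl group of compound 1 had stood apart from the others at this position, and compound 4 shows that a group without a hydroxy substituent can also raise the number beyond the scatter. The remaining step of an at least 1.7-fold lower number from compound 1 to compound 4 (0.23 log units; that floor lies within the scatter) is only a floor, because it starts from a limit of the assay: the limit of > 50000 nM in this assay, at which 1 of the 4 values shown sits.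

The compounds shown do not separate the contribution of the methyl from that of the nitro group, as the two enter together on one ring. In this assay they also leave open how a phenyl ring carrying only a methyl, only a nitro group or a carboxylic acid would read.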